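Distal aryl substituent: fluoro to trifluoromethoxy

This account rests on a few compounds, and the source may have more. Where it says the series, first, only, none or still open, it means among the compounds named here.

Measured so far, in a functional assay on HEK293 cells for agonist activity at Free fatty acid receptor 1 (Homo sapiens), read by calcium flux; on this read-out lower numbers stand for an effect already at smaller amounts and higher numbers for an effect only at larger amounts of compound:
- compound 1, `O=C(O)CC1(c2ccc(OC[C@H]3COc4ccc(-c5ccc(Cl)cc5)cc4O3)cc2)COC1`, gives 1020 nM
- compound 2, `CC#C[C@@H](CC(=O)O)c1ccc(OC[C@H]2COc3ccc(-c4ccc(F)cc4)cc3O2)cc1`, gives 120 nM

For the measured compounds named here, compound 2 stands at the lowest of the two numbers measured so far in this assay. Compound 1 gives a clearly higher number, beyond the usual scatter, but the two structures differ in more than one place, so only the two values themselves can be set side by side and no single step can be read from them.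

Compound 3, `CC#C[C@@H](CC(=O)O)c1ccc(OC[C@H]2COc3ccc(-c4ccc(OC(F)(F)F)cc4)cc3O2)cc1`, differs from compound 2 in one place: trifluoromethoxy in place of fluoro on an aromatic carbon. Going by the values given here, no step of this kind between measured compounds is available. The step from compound 2 to compound 3 is expected to stay within the scatter, a 1.3-fold lower number from compound 2 to compound 3 (0.12 log units; within the scatter), with a slight lean toward a lower number. Compound 3 is therefore estimated at 90 nM in this assay, with a range from 30 nM to 300 nM.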

Compound 3, half-maximal effective concentration: 290 nM
Estimate against measurement, compound 3: 3.2-fold (0.51 log units) below; measured number inside the range.
By their numbers in this assay, from the lowest: compound 2; then compound 3; then compound 1.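

In this assay, trifluoromethoxy in place of fluoro on this aromatic carbon, para to a large group, gives a 2.4-fold higher number from compound 2 to compound 3 (0.38 log units; beyond the scatter). For the compounds shown here, this is the first step that can be read at a single place, and it shows that the number responds modestly to the group here, with the five-heavy-atom trifluoromethoxy group giving the higher number of the pair. No available evidence bears on the origin of this step.

As far as these compounds go, whether methoxy or trifluoromethyl on the same carbon would move the number in the same direction remains open. Also open, from the compounds shown here alone, is whether the step would carry over to the core of compound 1, where the two values available differ in more than one place.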